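Cyclohexyl to tert-butoxycarbonyl on compound 2

The compounds below may be only part of what the source reports. "The series", "measured", "known", "first", "only" and "open" are said of these compounds alone.

In a functional assay (strain AB) with Danio rerio as the target, read by microscopy, with a stated time of 1 h (on this read-out higher numbers stand for an effect only at larger amounts of compound and lower numbers for an effect already at smaller amounts), compound 2 `NC(=O)c1c(NC(=O)Nc2ccc(Cl)cc2)sc2c1CCN(CC1CCCCC1)C2` gives 1890 nM, the highest of the three numbers measured. Compound 1 `C[N+]1(CC2CCCCC2)CCc2c(sc(NC(=O)Nc3ccc(Cl)cc3)c2C(N)=O)C1` gives 100 nM and compound 3 `CC(C)(C)C[N+]1(C)CCc2c(sc(NC(=O)Nc3ccc(Cl)cc3)c2C(N)=O)C1` gives 290 nM. Compound 4 `CC(C)(C)OC(=O)CN1CCc2c(sc(NC(=O)Nc3ccc(Cl)cc3)c2C(N)=O)C1` differs from compound 2 by tert-butoxycarbonyl in place of cyclohexyl on a saturated chain carbon bound to an amine nitrogen in a ring. Going by the values given here, only one measured step bears on this, and loosely: a 2.9-fold higher number from compound 1 to compound 3 (0.46 log units; beyond the scatter), a modest step beyond the scatter for tert-butyl in place of cyclohexyl. Among the compounds with values here, no measured compound carries the entering group. A modest step to a higher number is therefore expected in this assay, an estimated 1.6-fold higher number from compound 2 to compound 4 (0.20 log units; within the scatter). For compound 4 the estimated value is 3000 nM, with an expected range of 800 nM to 11000 nM.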

Compound 4, half-maximal effective concentration: > 25000 nM
Compound 4: a limit, no number (the forecaster's own chance of this, stated with the estimate: 15%); middle value at least 8.3-fold (0.92 log units) from the limit.
By their numbers in this assay, from the lowest: compound 1; then compound 3; then compound 2. At a limit, above all of these: compound 4.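

this assay places compound 4 at a limit, not a number: the limit of > 25000 nM in this assay, at which 1 of the 4 values shown sits. The earlier compounds shown here showed only a modest effect of replacing cyclohexyl, whereas an at least 13-fold higher number from compound 2 to compound 4 (1.12 log units; beyond the scatter) shows that a change on this saturated chain carbon bound to an amine nitrogen in a ring can carry a large penalty. The position is therefore not open to every group of similar heavy-atom size. The compounds shown do not separate the loss of the ring from the entry of the two oxygens, and whether a carboxylic acid or a phenyl group at this place would behave like tert-butoxycarbonyl remains open.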